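Removing the pyrazole from compound 2

This account rests on a few compounds, and the source may have more. Where it says the series, first, only, none or still open, it means among the compounds named here.

Compound 1 `C[C@@H]1CCCN1c1c(C#N)c2c(N)nc(Nc3cn(C)nc3Cl)nc2n1C`: 34 nM
Compound 2 `C[C@@H]1CCCN1c1c(C#N)c2c(N)nc(Nc3cn[nH]c3)nc2n1C`: 6 nM
Compound 3 `Cc1nn(C2CCOC2)cc1Nc1nc(N)c2c(C#N)c(N3CCC[C@H]3C)n(C)c2n1`: 19 nM; 44 nM (2 entries)
Compound 4 `C[C@@H]1CCCN1c1c(C#N)c2c(N)nc(N)nc2n1C`: not yet measured

Of the compounds shown here, three share one core and have been tested in an assay on isolated protein for inhibition of Leucine-rich repeat serine/threonine-protein kinase 2 (Homo sapiens), read by TR-FRET and LanthaScreen, with stated times of 50 min and 30 min, in the presence of a further agent that is not named here; a lower number here means a stronger inhibitor, a higher number a weaker inhibitor. Compound 2 stands lowest of the two single numbers there; compound 1 sits higher, and that gap, a 5.7-fold lower number from compound 1 to compound 2 (0.75 log units; beyond the scatter), is beyond the usual scatter. Compound 3 has two entries rather than one number, and the several entries of compound 3 in this assay, 19 nM; 44 nM (2 entries) shows how far repeat readings of the same compound can drift in this assay.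

Compound 4 differs from compound 2 in one place: hydrogen in place of 1H-pyrazol-4-yl on a nitrogen on an aromatic ring. Going by the values given here, no measured step matches this change. Among the compounds with values here, the only step on record, from compound 1 to compound 2, alters the substituents of the pyrazole and keeps the ring itself; it says nothing direct about removing the ring altogether. The change from compound 2 to compound 4 strips away a whole ring together with its hydrogen-bond donor and acceptor, so the author expects a markedly higher number in this assay, a loss well beyond the scatter, as a 100-fold higher number from compound 2 to compound 4 (2.00 log units; beyond the scatter) expresses. The author therefore estimates compound 4 at 600 nM, within a range from 100 nM to 5000 nM.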

Compound 4, half-maximal inhibitory concentration: 248 nM
For compound 4 the middle estimate is 2.4-fold (0.38 log units) above the measured one; the range from low to high includes it.
By their numbers in this assay, from the lowest: compound 2; then compound 1; then compound 4.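

On a nitrogen on an aromatic ring, the presence of the ring counts for more in this assay than the substituents it carries: hydrogen in place of 1H-pyrazol-4-yl gives a large step (a 41-fold higher number from compound 2 to compound 4 (1.62 log units; beyond the scatter)), whereas the earlier change of pyrazole substituents was modest (a 5.7-fold lower number from compound 1 to compound 2 (0.75 log units; beyond the scatter)). Even 3-chloro-1-methyl-1H-pyrazol-4-yl, the ring with the higher number of the two, still stands clearly ahead of hydrogen (a 7.3-fold higher number from compound 1 to compound 4 (0.86 log units; beyond the scatter)), so both rings with single numbers give lower numbers than the plain amino compound. Both of these new steps are wider than the drift between repeat readings of a single compound: the several entries of compound 3 in this assay, 19 nM; 44 nM (2 entries).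

The compounds shown cannot separate the contribution of the ring as a whole from that of its hydrogen-bond donor or acceptor, and every ring on this nitrogen here is a pyrazole. They also leave open how far a small group on that nitrogen, such as methyl or acetyl, or a different ring, such as phenyl or pyridine, would bring the number back towards that of compound 2.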